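From 3-nitrophenyl to 4-nitrophenyl on the shared core

The compounds below may be only part of what the source reports. "The series", "measured", "known", "first", "only" and "open" are said of these compounds alone.

In a functional assay on MCF7 cells (Homo sapiens) for cytotoxicity, read by MTT assay, with a stated time of 96 h (on this read-out lower numbers stand for stronger inhibition and higher numbers for weaker inhibition), compound 2 `COc1cc(C(=O)c2cn(-c3ccc(F)cc3)cc2-c2cccc([N+](=O)[O-])c2)cc(OC)c1OC` gives 440 nM and compound 1 `COc1cc(C(=O)c2cn(-c3ccccc3)cc2-c2ccc([N+](=O)[O-])cc2)cc(OC)c1OC` gives 590 nM. Within the data shown here, these two values lie within the scatter of each other, so compound 2 stands level with the only other measured compound. Compound 3 `COc1cc(C(=O)c2cn(-c3ccc(F)cc3)cc2-c2ccc([N+](=O)[O-])cc2)cc(OC)c1OC` keeps the 4-fluorophenyl group of compound 2 and carries 4-nitrophenyl in place of 3-nitrophenyl on an aromatic carbon. Among the measured compounds shown here, no measured pair isolates this change. The nearest guide is compound 1, which also carries 4-nitrophenyl and gives 590 nM. On that basis, no step beyond the scatter is expected in this assay, and no direction can be favoured. The expected step is a 1.0-fold higher number from compound 2 to compound 3 (0.01 log units; within the scatter). For compound 3 the estimated value is 450 nM, with an expected range from 180 nM to 1100 nM.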

Compound 3, half-maximal inhibitory concentration: 240 nM
Compound 3: middle estimate off by 1.9-fold (0.27 log units), on the high side, within the range that was stated.
By their numbers in this assay, from the lowest: compounds 3, 2 and 1 (each within the scatter of the next, the first and the last beyond it).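

In this assay, 4-nitrophenyl in place of 3-nitrophenyl gives a 1.8-fold lower number from compound 2 to compound 3 (0.26 log units; within the scatter) on the shared core, so with the 4-fluorophenyl group held constant, these two nitrophenyl groups cannot be told apart at this position. Fluoro in place of hydrogen on an aromatic carbon gives a 2.5-fold lower number from compound 1 to compound 3 (0.39 log units; beyond the scatter) with 4-nitrophenyl held constant, a modest step and the first single-place change in the series to lie beyond the scatter. No measurement bears on the reason for either step.

The compounds shown leave open whether an amino group or a carboxylic acid in place of the nitro group would hold this level. As far as these compounds go, whether chloro or methoxy in place of fluoro would match the step seen with fluoro also remains open.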